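Swapping a thioether for a diether amine on a pyrazine core

The compounds below may be only part of what the source reports. "The series", "measured", "known", "first", "only" and "open" are said of these compounds alone.

Measured compounds:
compound 1 `CCc1nc(-c2ccc(Cl)cc2Cl)c(CC)nc1SC(C)CC`: 0.283 h
compound 2 `CCc1nc(-c2cnc(OC)nc2OC)c(CC)nc1NC(CC)CC`: 0.117 h
compound 3 `CCc1nc(NC(CC)CC)c(OC)nc1-c1ccc(OC)cc1C(F)(F)F`: 2 h

Of the compounds shown here, three have been measured in an in vitro ADME assay on microsomes (Homo sapiens) for metabolic stability; a higher number here means that the compound lasts longer, a lower number that the compound disappears faster. Compound 1 gives 0.283 h, which places it second highest of the three numbers: compound 2 is the nearer neighbour with 0.117 h, a lower number, while compound 3 is the furthest of the set with 2 h, a higher number. Both gaps to compound 1 lie beyond the scatter.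

The unmeasured compound 4 `CCc1nc(-c2ccc(Cl)cc2Cl)c(CC)nc1NC(COC)COC` differs from compound 1 in one place on the shared core: (2-methoxy-1-(methoxymethyl)ethyl)amino in place of (sec-butyl)sulfanyl on an aromatic carbon. Among the compounds with values here, no pair of measured compounds differs in a single place, so the size of this step cannot be read from the data; compound 2 and compound 3 share an amino group at this position but differ elsewhere too, and their values bracket compound 1 on both sides. The expectation is therefore a small step upward in this assay, of a size close to the scatter, from compound 1 to compound 4 of a 1.4-fold higher number from compound 1 to compound 4 (0.15 log units; within the scatter). Compound 4 is estimated at 0.4 h, with a range from 0.15 h to 1.1 h.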

Compound 4, half-life: 0.15 h
Compound 4: the middle estimate sits 2.7-fold (0.43 log units) above what was measured; the measured number falls inside the stated range.
By their numbers in this assay, from the lowest: compounds 2, 4 and 1 (each within the scatter of the next, the first and the last beyond it); then compound 3.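

In this assay, this position now has its first readable single change: (2-methoxy-1-(methoxymethyl)ethyl)amino in place of (sec-butyl)sulfanyl gives a 1.9-fold lower number from compound 1 to compound 4 (0.28 log units; within the scatter), a step printed as within the scatter. On this core, the aromatic carbon next to the ring nitrogen therefore accepts a larger, oxygen-bearing amino chain in place of the sulfur-linked chain without a change that this assay can separate from repeat variation, something compound 2 and compound 3 could not show, as they differ from compound 1 in more than one place. Nothing available explains the size of this step.

The compounds shown leave open whether a (sec-butyl)amino group on the same core would stand apart from either compound 1 or compound 4. They also leave open how a morpholine at this position would read in this assay.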